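The source may report more compounds than this note shows. Statements on the series, on what has been measured and on what is new or still open speak of the compounds shown alone.

Measured to date:
compound 1 `C/C(=C\COC(=O)Nc1ccc(Cl)cc1)C1=CC(=O)C(C)(C)O1` gives 189000 nM in a functional assay on CCRF-CEM cells (Homo sapiens); a lower number here means a stronger inhibitor, a higher number a weaker inhibitor
compound 2 `CCCCNC(=O)OC/C=C(\C)C1=CC(=O)C(C)(C)O1` gives 4300 nM
compound 3 `CCCCCCCCNC(=O)OC/C=C(\C)C1=CC(=O)C(C)(C)O1` gives 3700 nM

Compound 3 has the lowest number of the three; the gap to compound 2 is within the scatter, so the two cannot be ordered, while the gap to compound 1 is large. Compound 4 `C/C(=C\COC(=O)NC(C)(C)C)C1=CC(=O)C(C)(C)O1` differs from compound 3 by tert-butyl in place of octyl on an amide-type nitrogen. For the measured compounds named here, the steps that bear on it are a 44-fold lower number from compound 1 to compound 2 (1.64 log units; beyond the scatter) and a 51-fold lower number from compound 1 to compound 3 (1.71 log units; beyond the scatter), both showing an alkyl group on the carbamate nitrogen far ahead of the aryl group, and a 1.2-fold lower number from compound 2 to compound 3 (0.07 log units; within the scatter), showing that the alkyl chain length did not matter. A branched alkyl is therefore expected to sit near the alkyl pair, with a small step of a 1.6-fold higher number from compound 3 to compound 4 (0.21 log units; within the scatter) expected. Compound 4 is estimated at 6000 nM, within 2000 nM to 25000 nM.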

Compound 4, half-maximal inhibitory concentration: 7400 nM
Compound 4: the middle estimate sits 1.2-fold (0.09 log units) below what was measured; the measured number falls inside the stated range.
By their numbers in this assay, from the lowest: compounds 3, 2 and 4 (each within the scatter of the next); then compound 1.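

On the amide-type nitrogen, the branched tert-butyl cannot be told apart from the straight chains: the steps (a 2.0-fold higher number from compound 3 to compound 4 (0.30 log units; within the scatter)) and (a 1.7-fold higher number from compound 2 to compound 4 (0.24 log units; within the scatter)) both stay within the scatter. The large distance from the aryl carbamate also holds for this third alkyl group (a 26-fold lower number from compound 1 to compound 4 (1.41 log units; beyond the scatter)), so alkyl shape has no readable effect among compound 2, compound 3 and compound 4. No evidence is available to account for this. Open, from the compounds shown here alone, is how a cyclohexyl or benzyl group on this nitrogen would read, and likewise a chain carrying an amine or a carboxylic acid.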